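Expectation for a Substituted Phenyl Ring in Compound 3

The source may hold more compounds than are shown below. What is called first, only, known or untested is meant among the compounds shown, and "the series" means these compounds.

The starting point is compound 1, `O=C(O)CCc1ccc(OCc2nc(-c3ccccc3)no2)cc1`, which in a functional assay on CHO cells for agonist activity at Free fatty acid receptor 1 (Homo sapiens), read by FLIPR and calcium flux, in the presence of a further agent that is not named here (a higher number here means that more compound is needed for the effect, a lower number that less compound is needed), gives 1130 nM. Among the compounds with values here, only one other compound has been measured so far: compound 2, `O=C(O)CCc1ccc(OCc2nc(-c3cccc(C(F)(F)F)c3)no2)cc1`, which in this assay gives 1110 nM. Compound 1 therefore stands next to compound 2 with the two numbers within the scatter of each other, and no order between them can be read. Within the data shown here, the one measured step, a 1.0-fold lower number from compound 1 to compound 2 (0.01 log units; within the scatter), shows that decorating the phenyl ring at the far end of the shared core with a trifluoromethyl group left the number where it was.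

Compound 3, `Cc1cc(-c2noc(COc3ccc(CCC(=O)O)cc3)n2)ccc1F`, changes the same phenyl ring in a different way: 4-fluoro-3-methylphenyl in place of phenyl on an aromatic carbon. Among the measured compounds shown here, the only step that bears on it is the one from compound 1 to compound 2, and that step was within the scatter. The expectation for compound 3 in this assay is therefore no step beyond the scatter, a 1.1-fold lower number from compound 1 to compound 3 (0.05 log units; within the scatter). Compound 3 is accordingly estimated at 1000 nM, with a range from 400 nM to 2500 nM.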

Compound 3, half-maximal effective concentration: 2120 nM
Estimate against measurement, compound 3: 2.1-fold (0.33 log units) below; low and high end bracket the measured number.
By their numbers in this assay, from the lowest: compounds 2, 1 and 3 (each within the scatter of the next).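

Putting 4-fluoro-3-methylphenyl in place of phenyl on this aromatic carbon gives, in this assay, a 1.9-fold higher number from compound 1 to compound 3 (0.27 log units; within the scatter), so the step cannot be read as a real difference between the two compounds. The position has now taken a phenyl ring bearing both a fluorine and a methyl group, as well as the trifluoromethyl-bearing ring of compound 2, and in neither case does the number step beyond the scatter from compound 1. No supporting measurement bears on this result, so nothing can be said about what lies behind it.

Going by these compounds, it remains open whether a group of another kind on this phenyl ring, such as an amine or a methoxy group, or a pyridine ring in place of the phenyl, would produce a step beyond the scatter. Also open, on these data alone, is whether changes elsewhere on the shared core, such as a longer chain carrying the carboxylic acid, would matter more than the changes at this position.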